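Compound 4: a small step upward expected

A few compounds are considered here, and "the series" means these few. Any claim that something is new, unique, unknown or untested is made for them only; others in the source may bear on it.

Measured in a functional assay on HL-60 cells (Homo sapiens) for activation, read by flow cytometry, with a stated time of 4 days; a lower number here means that less compound is needed, a higher number that more compound is needed for the effect:
- Compound 1 `COc1ccc(-n2cnc3cnc(-c4ccccc4C)cc32)cc1OC`: 69 nM
- Compound 2 `COc1ccc(-n2cnc3cnc(-c4ccc(F)cc4OC)cc32)cc1OC`: 35 nM
- Compound 3 `COc1cc(F)ccc1-c1cc2c(cn1)ncn2-c1ccc(OC(F)F)cc1`: 93 nM

The value of compound 3 lies within the usual scatter of the value of compound 1, while compound 2 needs clearly less compound than compound 3 does.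

The next compound is compound 4 `Cc1cc(F)c(F)cc1-c1cc2c(cn1)ncn2-c1ccc(OC(F)F)cc1`, and its change is 4,5-difluoro-2-methylphenyl in place of 4-fluoro-2-methoxyphenyl on an aromatic carbon. Among the compounds with values here, one measured step bears on this swap, and it runs the opposite way: 4-fluoro-2-methoxyphenyl in place of 2-methylphenyl gave a 2.0-fold lower number from compound 1 to compound 2 (0.29 log units; within the scatter). Read backwards, that step points towards a slightly higher number in this assay, though only weakly. Within the data shown here, it was measured with a different group elsewhere on the shared core, and no measured step tests the 4,5-difluoro pattern.

The expected change is therefore small, an estimated 1.5-fold higher number from compound 3 to compound 4 (0.18 log units; within the scatter). For compound 4 the estimated value is 140 nM, with an expected range of 55 nM to 330 nM.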

Compound 4, half-maximal effective concentration in the HL-60 assay: 220 nM
For compound 4 the middle estimate is 1.6-fold (0.20 log units) below the measured one; the measured number falls inside the stated range.
By their numbers in the HL-60 assay, from the lowest: compounds 2, 1 and 3 (each within the scatter of the next, the first and the last beyond it); then compound 4.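

Within the data shown here, in the HL-60 assay, placing 4,5-difluoro-2-methylphenyl on this aromatic carbon next to the ring nitrogen gives a 2.4-fold higher number from compound 3 to compound 4 (0.37 log units; beyond the scatter), the first step at this position that lies beyond the scatter. The same swap also brings a gain in a second property, as a physicochemical assay for solubility (a higher number here means a more soluble compound, a lower number a less soluble compound), shows: the measured solubility of compound 3, 3000 nM, and of compound 4, 15000 nM, a 5.0-fold higher number (0.70 log units; beyond the scatter) In the physicochemical assay compound 3 gives 3000 nM and compound 4 gives 15000 nM. This position therefore influences both read-outs, and between these two compounds the higher amount of compound needed for the effect comes together with better solubility.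

The swap changes the methoxy group to methyl and adds a second fluorine at once, so these compounds cannot separate the contribution of each change. Also open, on these data alone, is whether an amine or a carboxylic acid on this aromatic ring would retain the solubility of compound 4 while lowering its number in the HL-60 assay.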